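The source may hold more compounds than are shown below. What is called first, only, known or untested is meant among the compounds shown, and "the series" means these compounds.

Measured compounds:
Compound 1, `Cc1cc(C)cc(S(=O)(=O)c2c(C(=O)NCC(=O)NCc3ccncc3)[nH]c3ccc(Cl)cc23)c1`, gives > 48900 nM in an ADME assay on MT4 cells (Homo sapiens) for cytotoxicity, read by MTT assay; on this read-out lower numbers stand for higher toxicity in this test and higher numbers for lower toxicity in this test.
Compound 2, `Cc1cc(C)cc(S(=O)(=O)c2c(C(=O)NC(C)c3cc(F)cc(F)c3)[nH]c3ccc(Cl)cc23)c1`, gives > 49700 nM in this assay.
Compound 3, `Cc1cc(C)cc(S(=O)(=O)c2c(C(=O)NCC(=O)NC(C)c3ccccc3F)[nH]c3ccc(Cl)cc23)c1`, gives 23000 nM in this assay.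

The value for compound 2 is a limit of the assay, not a number. The value for compound 1 is likewise a limit, so two of the three results shown sit at the limits the limit of > 48900 nM in this assay, at which 1 of the 3 values shown sits, and (the limit of > 49700 nM in this assay, at which 1 of the 3 values shown sits), and compound 3 alone gives a number. Compound 4, `Cc1cc(C)cc(S(=O)(=O)c2c(C(=O)NC(C)c3ccccc3F)[nH]c3ccc(Cl)cc23)c1`, is compound 2 with 2-fluorophenyl in place of 3,5-difluorophenyl on a saturated chain carbon bound to an amide-type nitrogen and a saturated chain carbon. Within the data shown here, no measured step covers this exchange directly. The step that the two limits leave unreadable from compound 1 to compound 2 is unreadable. Among the measured compounds shown here, the step of an at least 2.1-fold lower number from compound 1 to compound 3 (0.32 log units; beyond the scatter) introduces the same 1-(2-fluorophenyl)ethyl group, though on a longer chain than in compound 4, and gives the one numeric value. Compound 4 is therefore expected to land near the top of the range, with a step of an at least 1.2-fold lower number from compound 2 to compound 4 (0.09 log units; that floor lies within the scatter) that may well again end at a limit. The estimate for compound 4 is 40000 nM, between 15000 nM and 60000 nM.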

Compound 4, half-maximal cytotoxic concentration: > 51500 nM
Compound 4 ended at the assay's limit; the forecaster's own chance of this, stated with the estimate: 55%; middle value at least 1.2-fold (0.10 log units) from the limit.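

Compound 4, like compound 1 and compound 2, ends at a limit of this assay, and the steps to compound 4 from these two compounds cannot be read. The compounds shown leave open whether 2-fluorophenyl in place of 3,5-difluorophenyl changes the number in this assay at all.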